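Swapping chloro for fluoro on a styryl oxime series

This account rests on a few compounds, and the source may have more. Where it says the series, first, only, none or still open, it means among the compounds named here.

Measured compounds:
- compound 1, `O/N=C(\C=C\c1ccc(F)cc1)c1ccc(Cl)cc1`: 11500 nM
- compound 2, `Cc1ccc(C(/C=C/c2ccc(Cl)cc2)=N/O)cc1`: 21300 nM

Both compounds were tested in an ADME assay on cells (Mus musculus, strain Balb/c) for cytotoxicity, read by MTT assay, with a stated time of 48 h; a lower number here means that less compound is tolerated, a higher number that more compound is tolerated. Compound 1 gives 11500 nM, while compound 2 gives 21300 nM. The two numbers stand within the usual scatter of each other, so no order between compound 1 and compound 2 can be claimed from these data; compound 2 is simply the reference point for the next step.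

Compound 3, `Cc1ccc(C(/C=C/c2ccc(F)cc2)=N/O)cc1`, has not yet been measured. Relative to compound 2 it carries one change: fluoro in place of chloro on an aromatic carbon. Among the measured compounds shown here, no measured pair shows the effect of this exchange on its own, so there is nothing to draw on but the two values above, which themselves lie close together.

Compound 3 is therefore expected to stay near compound 2, with an estimated step of a 1.3-fold lower number from compound 2 to compound 3 (0.10 log units; within the scatter) that need not exceed the scatter. The estimate for compound 3 is 17000 nM, with a range from 8000 nM to 36000 nM.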

Compound 3, half-maximal cytotoxic concentration: 13200 nM
The estimate for compound 3 lay 1.3-fold (0.11 log units) above the measured number; measured number inside the range.
By their numbers in this assay, from the lowest: compounds 1, 3 and 2 (each within the scatter of the next).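

In this assay, the exchange of chloro for fluoro on an aromatic carbon, para to a large group, now has a measured pair of its own, with a 1.6-fold lower number from compound 2 to compound 3 (0.21 log units; within the scatter). The second pair, which differs by a single exchange of its own, gives a 1.1-fold higher number from compound 1 to compound 3 (0.06 log units; within the scatter), so neither single exchange separates its two compounds in these data. No measurement beyond these numbers bears on either step.

The compounds shown carry only chloro, fluoro or methyl at these places, so it remains open whether an amine, a carboxylic acid or a longer chain on the same aromatic carbon would give a step beyond the scatter. Every compound shown also keeps the oxime, which leaves its part in these numbers open.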